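The compounds below may be only part of what the source reports. "The series", "measured", "known", "first", "only" and "open" are said of these compounds alone.

Measured so far in this series:

compound 1 `CCc1ccc(N(CC(C)C)S(=O)(=O)c2ccc3c(c2)C(C)CC(C2CCOCC2)O3)cc1`, 5.71
compound 2 `CCc1ccc(N(CC(C)C)S(=O)(=O)c2ccc3nc(C4CCOCC4)cc(O)c3c2)cc1`, 4.97
compound 3 `O=S(=O)(c1ccc2c(c1)C(O)CC(C1CCOCC1)O2)N1CCC(c2ccccc2)CC1`, 2.63

In a physicochemical assay for lipophilicity, at pH 7.4 (on this read-out higher numbers stand for higher lipophilicity and lower numbers for lower lipophilicity), compound 1 stands highest of the three numbers. Compound 2 comes nearest, with a number lower than that of compound 1 by a margin beyond the scatter, and compound 3 sits furthest below, again beyond the scatter. For the measured compounds named here, no single-point step between any two of these measured compounds is available, so nothing more than the bare values can be said of those gaps.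

Compound 4 `CCc1ccc(N(CC(C)C)S(=O)(=O)c2ccc3c(c2)CCC(C2CCOCC2)O3)cc1` has not yet been measured. It differs from compound 1 by hydrogen in place of methyl on a saturated ring carbon. Removing one carbon from a saturated ring carbon is a minor trimming of the shared core, and in this assay the expected step of a number 0.36 log units lower from compound 1 to compound 4 (beyond the scatter) is small and downward, close to the edge of the scatter. Compound 4 is therefore estimated at 5.35, with a range from 4.95 to 5.75.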

Compound 4, distribution coefficient: 5.38
Compound 4: middle estimate off by 0.03 log units, on the low side, within the range that was stated.
By their numbers in this assay, from the lowest: compound 3; then compound 2; then compound 4; then compound 1.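

In this assay, for the compounds shown here, the saturated ring carbon two ring bonds from the ring atom bearing the oxan-4-yl group gives the first reading of a single change: hydrogen in place of methyl gives a number 0.33 log units lower from compound 1 to compound 4 (beyond the scatter). Going by these compounds alone, the gaps among the earlier compounds span differences in more than one place, whereas here only this one methyl differs, and it carries no hydrogen-bond donors or acceptors and no net charge. Nothing available gives a reason for the size of this step.

Open, as far as these compounds go, is how a longer chain, an amine or a carboxylic acid on this same ring carbon would compare with the methyl and the hydrogen. Also open, from the compounds shown here alone, is whether hydrogen in place of methyl gives a step of like size when the rest of the molecule differs.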